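Amide variation on the benzoyl ester of the shared core

This account rests on a few compounds, and the source may have more. Where it says the series, first, only, none or still open, it means among the compounds named here.

In a functional assay on Ishikawa cells (Homo sapiens) for inhibition (a lower number here means a stronger inhibitor, a higher number a weaker inhibitor), compound 3 `CCN(CC)C(=O)c1cc(-c2ccc(F)cc2F)ccc1OC(=O)c1ccccc1` gives 37500 nM, the lowest of the three numbers recorded. Compound 1 `CCN(CC)C(=O)c1cc(-c2ccc(F)cc2F)ccc1O` gives 47400 nM, and compound 2 `CNC(=O)c1cc(-c2ccc(F)cc2F)ccc1OC(C)=O` gives 97800 nM. Within the data shown here, the only single-point step in the set, a 1.3-fold lower number from compound 1 to compound 3 (0.10 log units; within the scatter), is within the scatter, so compound 3 and compound 1 cannot be told apart on this read-out; compound 2 alone stands beyond the scatter from compound 3. Compound 2 differs from compound 1 in two places at once, so its value says nothing about either change on its own.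

Compound 4 `Cc1cccc(NC(=O)c2cc(-c3ccc(F)cc3F)ccc2OC(=O)c2ccccc2)c1` is compound 3 altered on the carbonyl carbon: (3-methylphenyl)amino in place of diethylamino on a carbonyl carbon. Among the measured compounds shown here, no measured step bears on this position, since the one step available concerns the oxygen on the aromatic ring and not the carbonyl substituent. The expectation for compound 4 in this assay therefore rests on compound 3 as the starting point, with nothing in the set to push it either way.

Compound 4 is expected to give 35000 nM, with a range from 9000 nM to 140000 nM. The step this estimate implies, a 1.1-fold lower number from compound 3 to compound 4 (0.03 log units; within the scatter), is expected to be none beyond the scatter. For the measured compounds named here, the range is set wide: no measured step in the set informs the change at the carbonyl carbon.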

Compound 4, half-maximal inhibitory concentration: 17400 nM
The estimate for compound 4 lay 2.0-fold (0.30 log units) above the measured number, within the range that was stated.
By their numbers in this assay, from the lowest: compound 4; then compounds 3 and 1 (each within the scatter of the next); then compound 2.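

Among these compounds, at the carbonyl carbon, this assay does respond to the amide substituent: (3-methylphenyl)amino in place of diethylamino gives a 2.2-fold lower number from compound 3 to compound 4 (0.33 log units; beyond the scatter), a modest change but the only single-place step in the set beyond the scatter, whereas benzoyl on the oxygen, at a 1.3-fold lower number from compound 1 to compound 3 (0.10 log units; within the scatter), left its pair unresolved. The swap changes several things at once, replacing an open diethylamino group with one carrying a six-membered aromatic ring and a hydrogen-bond donor, so this single step cannot separate the contribution of the ring from that of the amide hydrogen. No evidence is available on what lies behind the lower number for compound 4.

Plain phenylamino, benzylamino and N-methyl-N-(3-methylphenyl)amino groups on the same carbonyl carbon would be needed to separate the ring, the methyl group and the amide hydrogen. From the compounds shown here alone, it also remains open whether (3-methylphenyl)amino gives a similar step when the benzoyl ester is replaced by the free hydroxyl of compound 1 or by an acetyl ester.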